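This account rests on a few compounds, and the source may have more. Where it says the series, first, only, none or still open, it means among the compounds named here.

Within the data shown here, in an ADME assay on microsomes from liver (Homo sapiens) for metabolic stability (a higher number here means faster removal of the compound, a lower number slower removal), compound 1 `O=C(Nc1cccc(Cl)c1)N1CCc2[nH]nc(-c3ccccc3)c2C1` gives 192 mL/min/kg and compound 2 `CC(C)ON(C)C(=O)c1n[nH]c2c1CN(C(=O)Nc1cccc(Cl)c1)CC2` gives 65 mL/min/kg as the lower of the two numbers so far. Among the measured compounds shown here, the only measured step is a 3.0-fold lower number from compound 1 to compound 2 (0.47 log units; beyond the scatter) with isopropoxy(methyl)carbamoyl in place of phenyl on an aromatic carbon. In compound 3 `O=C(Nc1cccc(Cl)c1)N1CCc2[nH]nc(C(=O)N3CCCCO3)c2C1` the change from compound 2 is a group of 6 heavy atoms (4 carbon, 1 nitrogen, 1 oxygen; one six-membered non-aromatic ring with 2 hetero atoms) in place of a group of 6 heavy atoms (4 carbon, 1 nitrogen, 1 oxygen; no ring), on a carbonyl carbon and it brings one six-membered non-aromatic ring where compound 2 has no ring. For the measured compounds named here, that measured step replaced a different group, so it does not test this ring and shows only that one change in this small set moved the number modestly. The value of compound 2 at 65 mL/min/kg is therefore the anchor for the expectation. No clear direction can be drawn, and a 1.1-fold lower number from compound 2 to compound 3 (0.03 log units; within the scatter) is the estimated step, expected to stay within the scatter. For compound 3 the estimate is 60 mL/min/kg with an expected range from 28 mL/min/kg to 125 mL/min/kg.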

Compound 3, clearance: 38 mL/min/kg
Estimate against measurement, compound 3: 1.6-fold (0.20 log units) above; the range from low to high includes it.
By their numbers in this assay, from the lowest: compounds 3 and 2 (each within the scatter of the next); then compound 1.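

In this assay, a six-membered non-aromatic ring with 2 hetero atoms in place of isopropoxy(methyl)amino on the carbonyl carbon gives a 1.7-fold lower number from compound 2 to compound 3 (0.23 log units; within the scatter), so at this place the ring and the open group cannot be told apart. The second carbonyl-linked group in place of phenyl also gives a step beyond the scatter, a 5.1-fold lower number from compound 1 to compound 3 (0.70 log units; beyond the scatter), which stands with a 3.0-fold lower number from compound 1 to compound 2 (0.47 log units; beyond the scatter), and neither of the compounds carrying such a group goes against this pattern. Nothing given here bears on the cause of these steps.

Still open, as far as these compounds go, is whether the number would hold with a piperidine or a dimethylamino group on the same carbonyl carbon, which would test the oxygen that both groups carry. Also open, from the compounds shown here alone, is whether a carboxylic acid at this place would fall with compound 2 and compound 3 or with compound 1.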